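The compounds below may be only part of what the source reports. "The series", "measured", "known", "first", "only" and "open" are said of these compounds alone.

The series shares one core. Compound 1 `CC(=O)Oc1ccc(C(=O)Nc2cc3ccc(OCC4CCN(C)C4)c(C)c3oc2=O)cc1CC=C(C)C` gives 880 nM in a functional assay on SK-BR-3 cells (Homo sapiens) for antiproliferative activity; a lower number here means a stronger inhibitor, a higher number a weaker inhibitor. Within the data shown here, compound 2 `CC(=O)Oc1ccc(C(=O)Nc2cc3ccc(OCCC4CCCCN4)c(C)c3oc2=O)cc1CC=C(C)C` gives 640 nM in this assay, and the only single-point step among the measured compounds, a 1.4-fold lower number from compound 1 to compound 2 (0.14 log units; within the scatter), exchanges the amine-bearing group on the ether chain without leaving the scatter. Compound 3 `CC(C)=CCc1cc(C(=O)Nc2cc3ccc(OCCCN(C)C(C)C)c(C)c3oc2=O)ccc1O` gives 570 nM in this assay. Its number is the smallest of the three on paper, yet its gaps to compound 2 and to compound 1 both lie within the scatter, so it cannot be set apart from either of them.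

Compound 4 `CC(C)=CCc1cc(C(=O)Nc2cc3ccc(OCCCNCc4ccccc4)c(C)c3oc2=O)ccc1O` differs from compound 3 by benzylamino in place of isopropyl(methyl)amino on a saturated chain carbon, three bonds along the chain from an oxygen on an aromatic ring. Among the measured compounds shown here, the only measured step that speaks to such an exchange is the one from compound 1 to compound 2, where a different amine on the ether chain stayed within the scatter; no measured pair shows benzylamino itself. On that basis the step of a 1.0-fold lower number from compound 3 to compound 4 (0.02 log units; within the scatter) is expected to remain within the scatter, in no particular direction. Compound 4 is therefore estimated at 550 nM in this assay, with a range from 250 nM to 1200 nM.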

Compound 4, half-maximal inhibitory concentration: 470 nM
Beside the measured number, compound 4's estimate is 1.2-fold (0.07 log units) above it; the measured number falls inside the stated range.
By their numbers in this assay, from the lowest: compounds 4, 3, 2 and 1 (each within the scatter of the next).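

Across a 1.2-fold lower number from compound 3 to compound 4 (0.08 log units; within the scatter), the isopropyl(methyl)amino group on a saturated chain carbon, three bonds along the chain from an oxygen on an aromatic ring, gives way to benzylamino, and the result in this assay stays within the scatter. Among these compounds, this is the first measured step at this position to bring in a six-membered aromatic ring of carbon only and a hydrogen-bond donor, whereas the step from compound 1 to compound 2 exchanged only saturated amine-bearing groups. Compounds 3 and 4 thus show that an open-chain amine with no ring and one carrying a benzyl group cannot be told apart here, although no information is available on why the exchange leaves the number within the scatter.

Whether the nitrogen itself matters remains open, as no chain ending in a hydroxyl group or a carboxylic acid appears among these compounds. Also open, as far as these compounds go, is how a morpholine at the chain end, a substituted benzyl such as 4-fluorobenzyl, or a longer chain bearing benzylamino would read in this assay.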